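The source may hold more compounds than are shown below. What is called first, only, known or untested is meant among the compounds shown, and "the series" means these compounds.

Compound 1 `CCOC(=O)[C@@]12C[C@@H]1[C@@H](n1cnc3c(NC)nc(C#Cc4ccc(Cl)s4)cc31)[C@H](O)[C@@H]2O` gives 169 nM in an assay on HEK-293T cells for displacement of a labelled ligand from transmembrane domain-containing protein TMIGD3 (Homo sapiens), read by scintillation counting and radioligand binding, with stated times of 10 min and 90 min; on this read-out higher numbers stand for weaker inhibition and lower numbers for stronger inhibition.
Compound 2 `CCCCOC(=O)[C@@]12C[C@@H]1[C@@H](n1cnc3c(NC)nc(C#Cc4ccc(Cl)s4)nc31)[C@H](O)[C@@H]2O` gives 17.5 nM in this assay.
Compound 3 `CNc1nc(C#Cc2ccc(Cl)s2)nc2c1ncn2[C@H]1[C@H](O)[C@H](O)[C@]2(C(=O)OCCC(C)C)C[C@H]12` gives 24.4 nM in this assay.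

Among these three, compound 3 holds the second highest number in this assay. Its nearest neighbour is compound 2, reached by a 1.4-fold higher number from compound 2 to compound 3 (0.14 log units; within the scatter), a step within the scatter. Compound 1 stands furthest away, and its number in this assay lies beyond the scatter from that of compound 3.

Compound 4 `CNc1nc(C#Cc2ccc(Cl)s2)nc2c1ncn2[C@H]1[C@H](O)[C@H](O)[C@]2(C(=O)OCCc3ccccc3)C[C@H]12` differs from compound 3 in one place: phenyl in place of isopropyl on a saturated chain carbon, two bonds along the chain from an oxygen next to a carbonyl group. Among the measured compounds shown here, only one measured step touches this ester chain, namely a 1.4-fold higher number from compound 2 to compound 3 (0.14 log units; within the scatter), and it stayed within the scatter when a methyl was added to the chain. For the measured compounds named here, no measured step replaces a branched alkyl group by an aromatic ring at this position, so the data give no direct guide to the size of the change. Going by the values given here, the one available step suggests that alterations of the ester chain leave the number roughly where it is, so the step of a 1.2-fold higher number from compound 3 to compound 4 (0.09 log units; within the scatter) is expected to remain within the scatter. On that basis compound 4 is estimated to give 30 nM in this assay, with a range from 10 nM to 90 nM.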

Compound 4, inhibition constant: 262 nM
The estimate for compound 4 lay 8.7-fold (0.94 log units) below the measured number, and the stated range ends below it.
By their numbers in this assay, from the lowest: compounds 2 and 3 (each within the scatter of the next); then compounds 1 and 4 (each within the scatter of the next).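

In this assay, among the compounds shown here, the ester chain proves far less forgiving than the one earlier step suggested: phenyl in place of isopropyl gives an 11-fold higher number from compound 3 to compound 4 (1.03 log units; beyond the scatter), and phenyl in place of ethyl gives a 15-fold higher number from compound 2 to compound 4 (1.18 log units; beyond the scatter), whereas the added methyl gave only a 1.4-fold higher number from compound 2 to compound 3 (0.14 log units; within the scatter). At this place on the chain, two bonds along from the oxygen next to the carbonyl group, the two alkyl ends therefore read alike, while the phenyl end weakens inhibition markedly from either of them. Nothing available explains this loss.

The compounds shown leave open whether a saturated ring such as cyclohexyl at this place would read like the phenyl of compound 4 or like the alkyl ends of compound 2 and compound 3, and so whether the higher number goes with the aromatic ring itself or simply with the larger group. They also leave open how a pyridyl ring in place of the phenyl, or a longer chain carrying the phenyl further out from the ester oxygen, would read.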